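The source may hold more compounds than are shown below. What is called first, only, known or untested is meant among the compounds shown, and "the series" means these compounds.

Working notes on the series. Compound 3 `Cc1cc(S(=O)(=O)N2C=CNC(=O)[C@H]2CC(=O)N2CCC(N(C)C)CC2)c(C)cc1Cl` sits at the top of the three numbers in an in vitro functional assay on cells for antagonist activity at B1 bradykinin receptor (Homo sapiens), read by luminescence and calcium flux, with a stated time of 2 h; on this read-out lower numbers stand for stronger inhibition and higher numbers for weaker inhibition: compound 3 gives 152 nM, while compound 1 `Cc1ccc(S(=O)(=O)N2C=CNC(=O)[C@H]2CC(=O)N[C@@H]2CCCc3ccccc32)cc1` gives 3.3 nM and compound 2 `Cc1cc(S(=O)(=O)N2C=CNC(=O)[C@H]2CC(=O)N[C@H]2CCNCC2(C)C)c(C)cc1Cl` gives 0.31 nM. Among the compounds with values here, the only single-place step measured so far, a 490-fold higher number from compound 2 to compound 3 (2.69 log units; beyond the scatter), exchanges one ring amine for another on the carbonyl carbon and is large. Compound 4 `Cc1cc(S(=O)(=O)N2C=CNC(=O)[C@H]2CC(=O)N2CCCC(N(C)C)CC2)c(C)cc1Cl` differs from compound 3 only in a group of 10 heavy atoms (8 carbon, 2 nitrogen; one seven-membered non-aromatic ring with 1 hetero atom) in place of a group of 9 heavy atoms (7 carbon, 2 nitrogen; one six-membered non-aromatic ring with 1 hetero atom), on a carbonyl carbon. Within the data shown here, no measured step tests a change of ring size at this position; the large size of a 490-fold higher number from compound 2 to compound 3 (2.69 log units; beyond the scatter) shows that the group on this carbonyl carbon matters, yet that step is not a ring expansion and sets no direction for the present one. The expectation for compound 4 is therefore a number near that of compound 3, with the step of a 1.0-fold lower number from compound 3 to compound 4 (0.01 log units; within the scatter) expected to stay within the scatter. The estimate for compound 4 in this assay is 150 nM, with a range from 50 nM to 450 nM.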

Compound 4, half-maximal inhibitory concentration: 2.7 nM
Estimate against measurement, compound 4: 56-fold (1.74 log units) above; the measured number lies below the stated range.
By their numbers in this assay, from the lowest: compound 2; then compounds 4 and 1 (each within the scatter of the next); then compound 3.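

In this assay, ring size in the amine on this carbonyl carbon proves to be a strong determinant: a 56-fold lower number from compound 3 to compound 4 (1.75 log units; beyond the scatter) is large, although the counted hydrogen-bond donors and acceptors of the two groups are the same. The seven-membered group closes much of the gap opened by a 490-fold higher number from compound 2 to compound 3 (2.69 log units; beyond the scatter) but not all of it, as an 8.7-fold higher number from compound 2 to compound 4 (0.94 log units; beyond the scatter) remains beyond the scatter. No available evidence bears on this result.

Going by these compounds, only six- and seven-membered rings carrying the dimethylamino group can be compared here, so it remains open how a five-membered pyrrolidine or an eight-membered ring would read on this carbonyl carbon. Also open, on these data alone, is whether a primary amine in place of the dimethylamino group would keep the gain seen with the seven-membered ring.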